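This account rests on a few compounds, and the source may have more. Where it says the series, first, only, none or still open, it means among the compounds named here.

Series notes, an ADME assay on MDBK cells (Bos taurus) for cytotoxicity; on this read-out higher numbers stand for lower toxicity in this test and lower numbers for higher toxicity in this test.
Compound 1 `Fc1cccc(F)c1Cn1c(-c2c(F)cccc2F)nc2cnccc21`: > 100000 nM, a limit of the assay and not a number.
Compound 2 `Fc1cccc(F)c1Cn1c(-c2c(F)cccc2F)nc2ccncc21`: 99000 nM.
Compound 3 `COc1ccccc1Cn1ccc2nc(-c3ccccc3)nc-2c1`: > 100000 nM, again a limit of the assay and not a number.

Compound 3 therefore stands at the limit of this assay with no value of its own; the same limit covers two of the three values shown (the limit of > 100000 nM in this assay, at which 2 of the 3 values shown sit). Compound 4 `Ic1ccc(Cn2ccc3nc(-c4ccccc4)nc-3c2)cc1` is not yet measured. It differs from compound 3 by 4-iodophenyl in place of 2-methoxyphenyl on a saturated chain carbon bound to an aromatic nitrogen. Going by the values given here, no step between measured compounds is available for comparison, so the size of this change rests on expectation alone. For compound 4 a modest fall in this assay is expected, perhaps just beyond the scatter, which would mean an at least 1.6-fold lower number from compound 3 to compound 4 (0.22 log units; that floor lies within the scatter). Compound 4 is estimated at 60000 nM, between 15000 nM and 150000 nM, with a fair chance that the readout is once more only a limit.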

Compound 4, half-maximal cytotoxic concentration: 22000 nM
For compound 4 the middle estimate is 2.7-fold (0.44 log units) above the measured one; measured number inside the range.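

In this assay, the place on a saturated chain carbon bound to an aromatic nitrogen proves sensitive to the group it carries: 4-iodophenyl in place of 2-methoxyphenyl gives an at least 4.5-fold lower number from compound 3 to compound 4 (0.65 log units; beyond the scatter). The size of this step has only a lower bound, as compound 3 carries a limit of the assay and not a number. Much of the series still rests on that limit: the limit of > 100000 nM in this assay, at which 2 of the 4 values shown sit.

Going by these compounds, how 4-methoxyphenyl or 2-iodophenyl would read at this place remains open, so the iodine and its ring position stay unseparated. On these data alone, the effect of an amine on the phenyl ring, or of a longer chain, is equally open.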